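From Amide to Amine: Estimating Compound 3

The source may hold more compounds than are shown below. What is called first, only, known or untested is meant among the compounds shown, and "the series" means these compounds.

Among the measured compounds shown here, in a functional assay on HCT-15 cells (Homo sapiens) for inhibition, read by sulforhodamine B assay, with a stated time of 48 h (a higher number here means a weaker inhibitor of growth, a lower number a stronger inhibitor of growth), compound 2 `CCCCCCCCCCCC[C@@H](O)[C@H]1CC[C@H]([C@H](O)CCCCCCCCCCN(C)C(=O)c2ccnn2C)O1` gives 10000 nM, the lower of the two numbers so far, and compound 1 `CCCCCCCCCCCC[C@@H](O)[C@H]1CC[C@H]([C@H](O)CCCCCCCCCCNC(=O)c2ccnn2C)O1` gives 100000 nM. Compound 3 `CCCCCCCCCCCC[C@@H](O)[C@H]1CC[C@H]([C@H](O)CCCCCCCCCCNCc2ccnn2C)O1` changes the same end of the chain: ((1-methyl-1H-pyrazol-5-yl)methyl)amino in place of methyl((1-methyl-1H-pyrazol-5-yl)carbonyl)amino on a saturated chain carbon, ten or more bonds along the chain from an oxygen on a saturated carbon and a saturated ring carbon. For the measured compounds named here, only one measured step bears on this, a 10-fold lower number from compound 1 to compound 2 (1.00 log units; beyond the scatter), a modest change with methyl in place of hydrogen on an amide-type nitrogen. Compound 3 loses the carbonyl, so that step transfers poorly and no clear shift beyond the scatter is expected. The expected change is a 1.7-fold lower number from compound 2 to compound 3 (0.22 log units; within the scatter). For compound 3 the estimated value is 6000 nM, with an expected range of 1000 nM to 30000 nM.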

Compound 3, concentration for 50% growth inhibition: 2000 nM
Beside the measured number, compound 3's estimate is 3.0-fold (0.48 log units) above it, within the range that was stated.
By their numbers in this assay, from the lowest: compound 3; then compound 2; then compound 1.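

Taking the carbonyl out of this end of the chain does not cost growth inhibition: ((1-methyl-1H-pyrazol-5-yl)methyl)amino in place of methyl((1-methyl-1H-pyrazol-5-yl)carbonyl)amino gives a 5.0-fold lower number from compound 2 to compound 3 (0.70 log units; beyond the scatter). With (1-methyl-1H-pyrazol-5-yl)methyl in place of (1-methyl-1H-pyrazol-5-yl)carbonyl on the nitrogen, the change is a 50-fold lower number from compound 1 to compound 3 (1.70 log units; beyond the scatter), a large step, so among these compounds an amide is not required here. No available measurement accounts for this gain. Still open, from the compounds shown here alone, is whether a methyl on this amine nitrogen, giving a tertiary amine, would lower the number as it did on the amide nitrogen. Also open, going by these compounds, is whether a phenyl ring could replace the pyrazole.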